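The compounds below may be only part of what the source reports. "The series", "measured", "known", "first", "only" and "open" are said of these compounds alone.

Compound 1, `CCCOC(=O)C1=C(C)NC(=O)NC1c1ccoc1`, and compound 2, `CC1=C(C(=O)OCC(C)C)C(c2ccoc2)NC(=O)N1`, share one core and differ in a single spot: methyl in place of hydrogen on a saturated chain carbon bound to two saturated chain carbons. In an assay on membranes from HeLa cells for displacement of a labelled ligand from adenosine receptor A3 (Homo sapiens), read by scintillation counting, with a stated time of 180 min, tested at 1 uM (a higher number here means more inhibition at the concentration tested (going by the name of the read-out), a lower number less inhibition), compound 1 gives 11%, and compound 2 gives 16%, so the step is a number 5 percentage points higher from compound 1 to compound 2 (within the scatter); the two numbers cannot be told apart.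

Compound 3, `CCCOC(=O)C1=C(C)N(C)C(=O)NC1c1ccco1`, is built on a different core, and the difference between the two cores is not broken down here. In this assay compound 3 gives 8%, which sits within the scatter of both compound 1 and compound 2.

Compound 4, `CC1=C(C(=O)OCC(C)C)C(c2ccco2)NC(=O)N1C`, is not yet measured. It stands to compound 3 as compound 2 stands to compound 1, by the same change: methyl in place of hydrogen on a saturated chain carbon bound to two saturated chain carbons. Because the earlier step was a number 5 percentage points higher from compound 1 to compound 2 (within the scatter), the step from compound 3 to compound 4 is expected to be about as small, a number 4 percentage points higher from compound 3 to compound 4 (within the scatter). On that basis compound 4 is estimated to give 12% in this assay, with a likely range from 0% to 25%.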

Compound 4, a percentage reported as inhibition, at one concentration (the size of the read-out at that concentration, not a potency): 23%
For compound 4 the middle estimate is 11 percentage points below the measured one; measured number inside the range.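

In this assay, the change from propoxy to isobutoxy on the core of compound 3 comes out as a number 15 percentage points higher from compound 3 to compound 4 (beyond the scatter). Set beside the same change on the core of compound 1, this step cannot be told apart from the earlier one: the same change on two cores in this assay, a number 5 percentage points higher (within the scatter) from compound 1 to compound 2 and a number 15 percentage points higher (beyond the scatter) from compound 3 to compound 4, 10 percentage points apart, within the scatter of two such steps

So the two cores give no sign that the change behaves differently from one to the other, but two pairs read at a single concentration cannot show that it carries over unchanged, and they give no potency for any compound.

The compounds shown stop at propoxy and isobutoxy, so it remains open how the read-out would respond to a longer chain, such as a hexyloxy group, or to an ester chain ending in an amine. As far as these compounds go, it also remains open whether the same change would give a similar step on any core beyond these two.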